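Bromine added to the phenyl group of compound 3

The source may hold more compounds than are shown below. What is called first, only, known or untested is meant among the compounds shown, and "the series" means these compounds.

In a functional assay on U-87MG ATCC cells for inhibition, with U-87 MG (Homo sapiens) as the target, read by MTT assay, with a stated time of 48 h (a lower number here means a stronger inhibitor, a higher number a weaker inhibitor), the measured compounds give the following numbers:
compound 1, `COc1cc(/C=N/Nc2nc(-c3cccc(Br)c3)cs2)cc(Br)c1OC`: 86300 nM
compound 2, `COc1cc(/C=N/Nc2nc(-c3ccc(F)c(F)c3)cs2)c(Br)c(Br)c1OC`: 19600 nM
compound 3, `COc1cc(/C=N/Nc2nc(-c3ccccc3)cs2)c(Br)c(Br)c1OC`: 20100 nM

Compound 3 holds the second highest of the three numbers in this assay. Its nearest neighbour is compound 2, which sits within the scatter of it, while compound 1 lies furthest away, beyond the scatter. Compound 4, `COc1cc(/C=N/Nc2nc(-c3cccc(Br)c3)cs2)c(Br)c(Br)c1OC`, differs from compound 3 in one place: bromo in place of hydrogen on an aromatic carbon.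

For the measured compounds named here, only one single-point step is available to judge this change. The step of a 1.0-fold higher number from compound 2 to compound 3 (0.01 log units; within the scatter) also alters the substituents on that same phenyl group and stays within the scatter, so in this series swapping groups on that ring has so far moved the number little. Compound 1 carries the same 3-bromophenyl group as compound 4 but differs from compound 3 in a second place as well, so its higher number cannot be attributed to the bromine alone. The step from compound 3 to compound 4 in this assay is therefore expected to be small, a 1.3-fold higher number from compound 3 to compound 4 (0.11 log units; within the scatter), with some allowance for a weaker result. Compound 4 is estimated at 26000 nM in this assay, within a range of 10000 nM to 70000 nM.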

Compound 4, half-maximal inhibitory concentration: 27600 nM
The estimate for compound 4 lay 1.1-fold (0.03 log units) below the measured number; low and high end bracket the measured number.
By their numbers in this assay, from the lowest: compounds 2, 3 and 4 (each within the scatter of the next); then compound 1.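

In this assay, the bromo on the phenyl group adds a second substituent type to a ring that had so far shown only a swap of fluorines for hydrogens, and it gives a 1.4-fold higher number from compound 3 to compound 4 (0.14 log units; within the scatter) and a 1.4-fold higher number from compound 2 to compound 4 (0.15 log units; within the scatter), so phenyl, 3,4-difluorophenyl and 3-bromophenyl cannot be told apart on this core. For the compounds shown here, the new compound also supplies the first step beyond the scatter, which lies outside this phenyl group: with 3-bromophenyl held constant, bromo in place of hydrogen on an aromatic carbon of the core gives a 3.1-fold lower number from compound 1 to compound 4 (0.50 log units; beyond the scatter). No measurement shown here explains either result.

Going by these compounds, it remains open whether an amine or a carboxylic acid on this phenyl group would move the number as little as the halogens do. On these data alone, it is equally open whether the phenyl group stays this tolerant on the core of compound 1.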